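Trimethoxyphenyl triazole amides: benzylic aryl swap

This account rests on a few compounds, and the source may have more. Where it says the series, first, only, none or still open, it means among the compounds named here.

Measured in a functional assay on HeLa cells (Homo sapiens) for antiproliferative activity, read by MTT assay, with a stated time of 48 h; a lower number here means a stronger inhibitor, a higher number a weaker inhibitor:
compound 1 `COc1cc(-c2nnc(SCC(=O)Nc3ccccc3)n2N)cc(OC)c1OC`: 8280 nM
compound 2 `COc1cc(-c2nnc(SCC(=O)Nc3ccccc3C)n2N)cc(OC)c1OC`: > 100000 nM, a limit
compound 3 `COc1cc(-c2nnc(SCC(=O)NCc3ccc(Cl)cc3)n2N)cc(OC)c1OC`: > 100000 nM, a limit

Compound 3 sits at the assay limit, with no number of its own. That limit is shared by compound 2 (the limit of > 100000 nM in this assay, at which 2 of the 3 values shown sit). Compound 4 `COc1ccc(CNC(=O)CSc2nnc(-c3cc(OC)c(OC)c(OC)c3)n2N)cc1OC` differs from compound 3 only by 3,4-dimethoxyphenyl in place of 4-chlorophenyl on a saturated chain carbon bound to an amide-type nitrogen. For the measured compounds named here, no measured step changes the aryl group of the benzyl; the steps that exist run elsewhere: an at least 12-fold higher number from compound 1 to compound 3 (1.08 log units; beyond the scatter), an at least 12-fold higher number from compound 1 to compound 2 (1.08 log units; beyond the scatter), and a step that the two limits leave unreadable from compound 2 to compound 3. With both neighbours of compound 4 at the limit, compound 4 is expected to give 80000 nM, in the range 20000 nM to 300000 nM, and is expected to stay close to the limit, the step being an at least 1.2-fold lower number from compound 3 to compound 4 (0.09 log units; that floor lies within the scatter).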

Compound 4, half-maximal inhibitory concentration: > 100000 nM
Compound 4 gave a limit, no number; the forecaster's own chance of this, stated with the estimate: 65%; middle value at least 1.2-fold (0.09 log units) from the limit.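

In this assay compound 4 gives a limit, not a number, so a second aryl group on the benzyl, 3,4-dimethoxyphenyl in place of 4-chlorophenyl, also yields no readable value: the limit of > 100000 nM in this assay, at which 3 of the 4 values shown sit. Replacing phenyl with 3,4-dimethoxybenzyl on the amide-type nitrogen gives an at least 12-fold higher number from compound 1 to compound 4 (1.08 log units; beyond the scatter). The steps from compound 3 to compound 4 and from compound 2 to compound 4 cannot be read, as both ends of each are limits.

On these data alone, the size of any aryl effect on the benzyl stays unknown. Also open, as far as these compounds go, is whether a benzyl carrying an amine or a carboxylic acid, or a phenethyl amide, would give a number in this assay.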